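Aroyl swap on the nitrophenyl chalcone amides

This account rests on a few compounds, and the source may have more. Where it says the series, first, only, none or still open, it means among the compounds named here.

Three analogues have been run in a functional assay on HCT-116 cells (Homo sapiens) for cytotoxicity, read by resazurin assay, with a stated time of 48 h; on this read-out higher numbers stand for an effect only at larger amounts of compound and lower numbers for an effect already at smaller amounts. Compound 1 `O=C(/C=C/c1ccco1)c1ccc(NC(=O)c2ccccc2)cc1` gives 42000 nM in this assay. Compound 2 `O=C(/C=C/c1cccc([N+](=O)[O-])c1)c1ccc(NC(=O)c2ccco2)cc1`, which carries the nitrophenyl chalcone arm and a furan-2-yl amide, gives 3400 nM. Compound 3 `O=C(/C=C/c1cccc([N+](=O)[O-])c1)c1ccc(NC(=O)c2cccs2)cc1` gives 2600 nM. Compound 3 holds the lowest of the three numbers; its nearest neighbour is compound 2, and the gap a 1.3-fold lower number from compound 2 to compound 3 (0.12 log units; within the scatter) does not separate the two. Compound 1 stands far off, but it differs from compound 3 in two places, so its number alone says nothing about either change.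

Compound 4 `O=C(/C=C/c1cccc([N+](=O)[O-])c1)c1ccc(NC(=O)c2ccccc2)cc1` differs from compound 3 by phenyl in place of thiophen-2-yl on a carbonyl carbon. Going by the values given here, the one step that bears on this position is the exchange at the same carbonyl carbon, a 1.3-fold lower number from compound 2 to compound 3 (0.12 log units; within the scatter), which stayed inside the scatter. On that basis compound 4 is expected to sit close to compound 3, with a 1.1-fold higher number from compound 3 to compound 4 (0.03 log units; within the scatter) as the estimated step and no direction beyond the scatter. The estimate for compound 4 is 2800 nM, with a range of 1200 nM to 7000 nM.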

Compound 4, half-maximal effective concentration: 4100 nM
Estimate against measurement, compound 4: 1.5-fold (0.17 log units) below; the range from low to high includes it.
By their numbers in this assay, from the lowest: compounds 3, 2 and 4 (each within the scatter of the next); then compound 1.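

At the carbonyl carbon bound to the amide-type nitrogen, the six-membered phenyl now joins the two five-membered rings with no separation in this assay: the steps are a 1.6-fold higher number from compound 3 to compound 4 (0.20 log units; within the scatter) and a 1.2-fold higher number from compound 2 to compound 4 (0.08 log units; within the scatter), so this exchange has not moved the number beyond the scatter in any of the three pairs. Going by these compounds alone, compound 4 also gives the first single-place reading on the chalcone arm, where 3-nitrophenyl in place of furan-2-yl gives a 10-fold lower number from compound 1 to compound 4 (1.01 log units; beyond the scatter), which ties the large gap to compound 1 to that arm and not to the amide group. No measurement in hand gives a reason for either result.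

Going by these compounds, whether an acetyl group or a benzoyl ring carrying a dimethylamino group would leave the scatter at the amide stays open. Also open, on these data alone, is whether the nitro group itself carries the step on the chalcone arm, or whether a plain phenyl or an amine-bearing phenyl would do the same.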